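The source may report more compounds than this note shows. Statements on the series, on what has been measured and on what is new or still open speak of the compounds shown alone.

Measured in an ADME assay on a cell-free system (plasma, Rattus norvegicus) for metabolic stability, read by LC-MS, with a stated time of 60 min, tested at 100 uM; a lower number here means that less of the compound is left, a higher number that more of the compound is left:
- compound 1 `Cc1c(OCCCCOc2ccc(F)c(C(=O)O)c2)ccc(C(=O)CC(C)(C)C)c1O`: 83%
- compound 2 `Cc1c(OCCCCOc2cccc(C(=O)O)c2)ccc(C(=O)CC(C)C)c1C`: 106%
- compound 3 `COc1ccc(C(=O)O)cc1OCCCCOc1ccc(C(=O)CC2CCCC2)c(O)c1C`: 103%

Compound 1 has the lowest number of the three, and both other compounds lie above it by more than the usual scatter. Compound 4 `Cc1c(OCCCCOc2ccc(C(=O)CC(C)(C)C)c(O)c2C)cccc1C(=O)O` has 3-carboxy-2-methylphenyl in place of 3-carboxy-4-fluorophenyl on an oxygen on a saturated carbon. Going by the values given here, no two measured compounds differ in only one place, so no measured step guides this change. Compound 2 at 106% and compound 3 at 103% both lack the group that leaves, which suggests a modest rise at most. The expected change in this assay, about the size of the scatter, is a number 10 percentage points higher from compound 1 to compound 4 (within the scatter). For compound 4 the estimate is 93%, with an expected range of 78% to 108%.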

Compound 4, percent of the compound remaining: 89%
Estimate against measurement, compound 4: 4 percentage points above; the measured number falls inside the stated range.
By their numbers in this assay, from the lowest: compounds 1 and 4 (each within the scatter of the next); then compounds 3 and 2 (each within the scatter of the next).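

In this assay, going by these compounds alone, putting 3-carboxy-2-methylphenyl in place of 3-carboxy-4-fluorophenyl on an oxygen on a saturated carbon gives a number 6 percentage points higher from compound 1 to compound 4 (within the scatter), the only pair here that differs in one place. On this position, then, the fluorine and methyl versions of the ring cannot be told apart by how much compound is left. Nothing measured here gives a cause for this result. From the compounds shown here alone, whether an amine in place of the carboxylic acid on this ring would shift the number remains open. So does whether the same swap behaves alike with a different chain on the ketone.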